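Amino in place of chloro on a dichloropurine cytotoxin

The source may hold more compounds than are shown below. What is called first, only, known or untested is meant among the compounds shown, and "the series" means these compounds.

Measured compounds:
compound 1 `ClCc1ccccc1Cn1cnc2c(Cl)nc(Cl)nc21` — 850 nM
compound 2 `ClCc1ccc(Cn2cnc3nc(Cl)nc(Cl)c32)cc1` — 6450 nM

In a functional assay on LOX IMVI cells (Homo sapiens) for cytotoxicity, read by sulforhodamine B assay, with a stated time of 48 h (on this read-out higher numbers stand for lower toxicity in this test and lower numbers for higher toxicity in this test), compound 1 gives 850 nM and compound 2 gives 6450 nM; the gap between these two values lies beyond the scatter, so compound 1 stands as the more toxic of the pair, with the lowest number of the two.

Compound 3 `Nc1nc(Cl)c2ncn(Cc3ccccc3CCl)c2n1` is not yet measured in this assay. It differs from compound 1 in one place: amino in place of chloro on an aromatic carbon. The core of compound 1 thus keeps one chloro group while the other is exchanged for an amino group, and the chloromethyl on the benzyl part is unchanged.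

Among the measured compounds shown here, no measured pair shows the effect of this exchange, so the expectation rests on compound 1 alone. In this assay a modest loss of toxicity is expected, with an estimated step of a 2.9-fold higher number from compound 1 to compound 3 (0.47 log units; beyond the scatter) toward higher numbers. For compound 3 the estimated value is 2500 nM, within a range from 700 nM to 9000 nM.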

Compound 3, concentration lethal to 50% of the cells: > 100000 nM
Compound 3 gave a limit, no number; the forecaster's own chance of this, stated with the estimate: 5%; middle value at least 40-fold (1.60 log units) away from the limit.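

In this assay, the position on an aromatic carbon between two ring nitrogen atoms turns out to matter greatly: amino in place of chloro there gives an at least 110-fold higher number from compound 1 to compound 3 (2.07 log units; beyond the scatter). Keeping the other chloro group and the chloromethyl on the benzyl part does not preserve toxicity in this test. For compound 3 the read-out is a limit and not a number, so the true size of the step stays unfixed: the limit of > 100000 nM in this assay, at which 1 of the 3 values shown sits.

Open, as far as these compounds go, is whether the change depends on losing the chloro group or on gaining the amino group; a methoxy or a dimethylamino group at the same place would speak to that. Also open, from the compounds shown here alone, is whether the same exchange on compound 2, or at the remaining chloro group, would have a comparable effect.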